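The source may hold more compounds than are shown below. What is called first, only, known or untested is meant among the compounds shown, and "the series" means these compounds.

Values in a functional assay on T-24 cells (Homo sapiens) for antiproliferative activity, read by sulforhodamine B assay, with a stated time of 72 h; on this read-out lower numbers stand for stronger inhibition and higher numbers for weaker inhibition:
- compound 1 `C=CCOC(=O)C1=C2C(=NC1=O)c1cccc3c(SCCC)ccc2c13`: 13100 nM
- compound 2 `O=C(COC(=O)C1=C2C(=NC1=O)c1cccc3cccc2c13)OCC(F)(F)C(F)(F)F`: 19000 nM
- compound 3 `CCCSC(=O)COC(=O)C1=C2C(=NC1=O)c1cccc3c(SCCC)ccc2c13`: 79100 nM

Compound 3, at 79100 nM, has the highest number of the three. Compound 4 `CCCSc1ccc2c3c(cccc13)C1=NC(=O)C(C(=O)OCC(=O)OCC(F)(F)C(F)(F)F)=C12` has 2,2,3,3,3-pentafluoropropoxy in place of propylsulfanyl on a carbonyl carbon. Among the measured compounds shown here, the one measured step that bears on this is a 6.0-fold higher number from compound 1 to compound 3 (0.78 log units; beyond the scatter), which brought in the (propylsulfanyl)carbonyl that now leaves. Compound 2 already carries the 2,2,3,3,3-pentafluoropropoxy group and gives 19000 nM, but its core lacks the propylsulfanyl that compound 3 and compound 4 share. For the measured compounds named here, no measured pair isolates the change itself, so the expectation rests on these two indirect comparisons. In this assay a modest move to a lower number is therefore expected, one that stays short of the full size of the measured step. The expected step is a 3.3-fold lower number from compound 3 to compound 4 (0.52 log units; beyond the scatter). For compound 4 the estimated value is 24000 nM, with an expected range from 8000 nM to 70000 nM.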

Compound 4, half-maximal inhibitory concentration: > 100000 nM
Compound 4: no number, only a limit; the forecaster's own chance of this, stated with the estimate: 5%; middle value at least 4.1-fold (0.61 log units) from the limit.
By their numbers in this assay, from the lowest: compounds 1 and 2 (each within the scatter of the next); then compound 3. At a limit, above all of these: compound 4.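

In this assay compound 4 gives no number, only a limit of the assay: the limit of > 100000 nM in this assay, at which 1 of the 4 values shown sits. Among the compounds shown here, with 2,2,3,3,3-pentafluoropropoxy in place of propylsulfanyl on a carbonyl carbon, the result is an at least 1.2-fold higher number from compound 3 to compound 4 (0.10 log units; that floor lies within the scatter), so this change brings no move to a lower number, though the floor alone fixes no size for the step. Propylsulfanyl in place of hydrogen on an aromatic carbon gives an at least 5.2-fold higher number from compound 2 to compound 4 (0.72 log units; beyond the scatter), and (2,2,3,3,3-pentafluoropropoxy)carbonyl in place of vinyl gives an at least 7.6-fold higher number from compound 1 to compound 4 (0.88 log units; beyond the scatter), so the standing of compound 2 does not carry over once propylsulfanyl is present.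

As far as these compounds go, how far compound 4 truly lies from compound 3 remains unknown. From the compounds shown here alone, whether an amine or a carboxylic acid on this carbonyl carbon would give a lower number stays open.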